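Cyclopropyl in place of propyl on compound 1

The source may report more compounds than this note shows. Statements on the series, on what has been measured and on what is new or still open speak of the compounds shown alone.

For the measured compounds named here, in a functional assay on DU-145 cells (Homo sapiens) for inhibition, read by trypan blue exclusion, with a stated time of 72 h (on this read-out lower numbers stand for stronger inhibition and higher numbers for weaker inhibition), compound 1 (`CCCn1c(=O)c(S(=O)(=O)c2ccc(F)cc2F)cc2cnc(Nc3ccc4[nH]ccc4c3)nc21`) gives 1000 nM and holds the lower of the two numbers measured so far. In this assay, going by the values given here, compound 2 (`Cn1c(=O)c(C(=O)Nc2ccc(F)cc2)cc2cnc(Nc3ccc4[nH]ccc4c3)nc21`) gives 5000 nM as the only other number, higher than that of compound 1 by more than the usual scatter. Compound 3 (`O=c1c(S(=O)(=O)c2ccc(F)cc2F)cc2cnc(Nc3ccc4[nH]ccc4c3)nc2n1C1CC1`) has cyclopropyl in place of propyl on an aromatic nitrogen, and the rest of compound 1 stays the same: cyclopropyl in place of propyl on an aromatic nitrogen. Among the compounds with values here, no two measured compounds differ in one place only, so the data give no direct measure of this change. A step within the scatter is expected in this assay and no direction is favoured. The expectation rests on compound 1 and its 1000 nM alone. The estimated move is no change at the digits printed from compound 1 to compound 3 (within the scatter) in size. Compound 3 is estimated at 1000 nM with an expected range of 300 nM to 3300 nM on this read-out.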

Compound 3, half-maximal inhibitory concentration: 500 nM
Beside the measured number, compound 3's estimate is 2.0-fold (0.30 log units) above it; measured number inside the range.
By their numbers in this assay, from the lowest: compounds 3 and 1 (each within the scatter of the next); then compound 2.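

Cyclopropyl in place of propyl on the aromatic nitrogen gives, in this assay, a 2.0-fold lower number from compound 1 to compound 3 (0.30 log units; within the scatter), the first direct reading at this position, and compound 1 and compound 3 cannot be told apart on it. This position therefore takes a three-membered non-aromatic ring of carbon in place of an open chain of the same heavy-atom count without a step beyond the scatter. The data shown offer no measurement that would account for how close the two numbers lie.

On these data alone, whether a longer chain such as pentyl, a larger ring such as cyclohexyl, or a chain ending in an amine on this nitrogen would give a step beyond the scatter stays open. Also open, as far as these compounds go, is whether cyclopropyl in place of propyl would read the same alongside the side group of compound 2, which differs from compound 1 and compound 3 in more than one place.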